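Removing the (1-bromoethenyl)carbonyl group from compound 2

The source may report more compounds than this note shows. Statements on the series, on what has been measured and on what is new or still open speak of the compounds shown alone.

In a functional assay on L1210 cells (Mus musculus) for antiproliferative activity, with a stated time of 48 h (a lower number here means a stronger inhibitor, a higher number a weaker inhibitor), compound 1 (`C=C(Br)C(=O)Nc1ccc(/C=C/C(=O)c2ccc(I)cc2)cc1`) gives 3400 nM and compound 2 (`C=C(Br)C(=O)Nc1ccc(/C=C/C(=O)c2ccc(OCC)cc2)cc1`) gives 240 nM as the lower of the two numbers. Within the data shown here, the only measured step, a 14-fold lower number from compound 1 to compound 2 (1.15 log units; beyond the scatter), swaps iodo for ethoxy on an aromatic carbon. Compound 3 (`CCOc1ccc(C(=O)/C=C/c2ccc(N)cc2)cc1`) departs from compound 2 elsewhere, by hydrogen in place of (1-bromoethenyl)carbonyl on a nitrogen on an aromatic ring, which turns ((1-bromoethenyl)carbonyl)amino into amino. Among the measured compounds shown here, no measured step touches that group, so the large step above shows only that this series can move far on a single change and gives no direct size here. Both measured compounds carry the group that compound 3 lacks, so the data offer no value without it. A large move to a higher number is still expected, since a whole group is lost. The estimated step is a 25-fold higher number from compound 2 to compound 3 (1.40 log units; beyond the scatter) in this direction. For compound 3 the expected value is 6000 nM within an estimated range of 1500 nM to 25000 nM in this assay.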

Compound 3, half-maximal inhibitory concentration: 21000 nM
For compound 3 the middle estimate is 3.5-fold (0.54 log units) below the measured one, within the range that was stated.
By their numbers in this assay, from the lowest: compound 2; then compound 1; then compound 3.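

In this assay, among these compounds, the first reading on the nitrogen on the aromatic ring gives an 88-fold higher number from compound 2 to compound 3 (1.94 log units; beyond the scatter) when ((1-bromoethenyl)carbonyl)amino becomes amino. With the ethoxy group held in place, the compound carrying the (1-bromoethenyl)carbonyl group and the one with the free amino group therefore stand far apart, a distance that the iodo-to-ethoxy swap could not reveal because both of those compounds keep the group. No measurement shown here explains this loss.

Because the whole group leaves in one step, the result cannot assign the effect to the bromine, the double bond or the carbonyl. From the compounds shown here alone, an acetyl group on the same nitrogen, or an acryloyl group without the bromine, would separate these parts, and it also remains open whether the step would have the same size with iodo in place of ethoxy.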